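The source may report more compounds than this note shows. Statements on the series, on what has been measured and on what is new or still open speak of the compounds shown alone.

Measured so far in an assay on HEK293 cells for displacement of a labelled ligand from 5-hydroxytryptamine receptor 6 (Homo sapiens), read by radioligand binding, with a stated time of 60 min, tested at 100 nM; a lower number here means less inhibition, a higher number more inhibition at the concentration tested (going by the name of the read-out):
- compound 1 `O=c1sc2cc(NS(=O)(=O)c3ccc4ccccc4c3)ccc2n1CCN1CCCC1` gives 0%
- compound 2 `O=c1sc2cc(NS(=O)(=O)c3ccc4ccccc4c3)ccc2n1CCN1CCCCC1` gives 4%
- compound 3 `O=c1sc2cc(S(=O)(=O)Nc3cccc4ccccc34)ccc2n1CCN1CCCC1` gives 0%

All three numbers lie together at the bottom of the scale. Compound 1 and compound 3 have the same atoms joined differently; the difference between the two cores is not broken down here. Within the core of compound 1, the change piperidin-1-yl in place of pyrrolidin-1-yl on a saturated chain carbon, two bonds along the chain from an aromatic nitrogen gives the step of a number 4 percentage points higher from compound 1 to compound 2 (within the scatter).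

Compound 4 `O=c1sc2cc(S(=O)(=O)Nc3cccc4ccccc34)ccc2n1CCN1CCCCC1` has not been measured. It carries the same change on the core of compound 3: piperidin-1-yl in place of pyrrolidin-1-yl on a saturated chain carbon, two bonds along the chain from an aromatic nitrogen. The place is the same in both pairs. Among the compounds with values here, the only guide is the single earlier step, which rests on compound 1 at 0% and stays within the scatter. From compound 3 at 0% the step of a number 3 percentage points higher from compound 3 to compound 4 (within the scatter) is expected, of the same small size. Compound 4 is therefore estimated at 3% in this assay, with a likely range from 0% to 12%.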

Compound 4, a percentage reported as inhibition, at one concentration (the size of the read-out at that concentration, not a potency): 3%
Compound 4: middle estimate and measured number agree at the digits printed, and the stated range covers the measured number.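

In this assay, piperidin-1-yl in place of pyrrolidin-1-yl on the core of compound 3 gives a number 3 percentage points higher from compound 3 to compound 4 (within the scatter), and the change reads alike on the two cores: the same change on two cores in this assay, a number 4 percentage points higher (within the scatter) from compound 1 to compound 2 and a number 3 percentage points higher (within the scatter) from compound 3 to compound 4, 1 percentage points apart, within the scatter of two such steps

So, on these two cores, the change carries over as a step within the scatter, and all four compounds stay at the bottom of the scale at the single concentration tested. This does not show a transferable effect of the change, since neither step stands clear of the scatter, and it gives no information on potency or on how the change would read on a core with clear inhibition.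

The compounds shown leave open how other amines, such as morpholin-4-yl or a dimethylamino group, would read in place of piperidin-1-yl, and how a longer chain would read in place of the ethyl chain of 2-(piperidin-1-yl)ethyl. They also leave open whether any core in this series gives inhibition clearly above this level in this assay.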